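Hydroxyphenyl-substituted pyridines: moving one hydroxyl from meta to para

A few compounds are considered here, and "the series" means these few. Any claim that something is new, unique, unknown or untested is made for them only; others in the source may bear on it.

Measured so far:
compound 1, `Oc1ccc(-c2cc(-c3ccccc3O)cc(-c3cccc(O)c3)n2)cc1`, 4850 nM
compound 2, `Oc1ccc(-c2cc(-c3cccc(O)c3)nc(-c3cccc(O)c3)c2)cc1`, 3810 nM

Of the compounds shown here, two have been measured in a functional assay on HCT-15 cells (Homo sapiens) for cytotoxicity, read by CCK-8 assay, with a stated time of 4 days; on this read-out lower numbers stand for stronger inhibition and higher numbers for weaker inhibition. Compound 1 gives 4850 nM and compound 2 gives 3810 nM. Compound 2 has the lowest of the two numbers, yet its nearest neighbour, compound 1, lies within the scatter of it, so the two values show no difference that can be trusted.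

Compound 3, `Oc1ccc(-c2cc(-c3ccc(O)cc3)nc(-c3cccc(O)c3)c2)cc1`, has not yet been measured. It differs from compound 2 in one place: 4-hydroxyphenyl in place of 3-hydroxyphenyl on an aromatic carbon next to the ring nitrogen. For the measured compounds named here, no measured pair shows this kind of swap, and the two measured compounds themselves sit within the scatter of each other. Compound 3 is therefore expected to give about 4000 nM, between 1800 nM and 9000 nM, which would mean a step of a 1.0-fold higher number from compound 2 to compound 3 (0.02 log units; within the scatter), expected to fall within the scatter.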

Compound 3, half-maximal inhibitory concentration: 3520 nM
For compound 3 the middle estimate is 1.1-fold (0.06 log units) above the measured one, within the range that was stated.
By their numbers in this assay, from the lowest: compounds 3, 2 and 1 (each within the scatter of the next).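

In this assay, 4-hydroxyphenyl in place of 3-hydroxyphenyl on an aromatic carbon next to the ring nitrogen gives a 1.1-fold lower number from compound 2 to compound 3 (0.03 log units; within the scatter), so the two hydroxyphenyl groups cannot be told apart at this position. For the other pair that differs in one hydroxyphenyl group, the result is a 1.4-fold lower number from compound 1 to compound 3 (0.14 log units; within the scatter), which is also within the scatter, so the three compounds stand level and the placing of the hydroxyl on this ring has no readable bearing on the number among them. No measurement that could explain this is at hand.

The compounds shown leave open whether an amine or a carboxylic acid in place of the hydroxyl on these rings would separate from this group of values. They also leave open what a methoxy group, or the removal of a hydroxyl altogether, would give on the same core.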